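A methoxy addition, repeated on a more potent core

A few compounds are considered here, and "the series" means these few. Any claim that something is new, unique, unknown or untested is made for them only; others in the source may bear on it.

Measured compounds:
- compound 1, `COc1ccc(C(=O)Nc2ccc(N(C)S(C)(=O)=O)c(OCc3cc(Cl)ccc3Cl)c2)cc1`: in a functional assay on SK-BR-3 cells (Homo sapiens) for antiproliferative activity, read by MTT assay, with a stated time of 48 h (on this read-out lower numbers stand for stronger inhibition and higher numbers for weaker inhibition), compound 1 gives 490 nM.
- compound 2, `COc1ccc(C(=O)Nc2ccc(N(C)S(C)(=O)=O)c(OCc3cc(Cl)ccc3Cl)c2)cc1OC`: in this assay compound 2 gives 3730 nM.
- compound 3, `COc1ccc(C(=O)Nc2ccc(NS(C)(=O)=O)c(OCc3cc(OC)ccc3OC)c2)cc1`: in this assay compound 3 gives 13.4 nM.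

Compound 2 differs from compound 1 in a single place: methoxy in place of hydrogen on an aromatic carbon. That change produced a 7.6-fold higher number from compound 1 to compound 2 (0.88 log units; beyond the scatter). Compound 3 is built on a different core; how its core differs from that of compound 1 is not broken down here, but compound 3 stands lowest of the three, beyond the scatter from both others.

Compound 4, `COc1ccc(OC)c(COc2cc(NC(=O)c3ccc(OC)c(OC)c3)ccc2NS(C)(=O)=O)c1`, is not yet measured. It differs from compound 3 by methoxy in place of hydrogen on an aromatic carbon. The surroundings of the place are the same as in the earlier pair, so this is the same change, now made on the core of compound 3. Since the earlier pair showed a 7.6-fold higher number from compound 1 to compound 2 (0.88 log units; beyond the scatter), a step in the same direction is expected here, a 5.2-fold higher number from compound 3 to compound 4 (0.72 log units; beyond the scatter), resting on that single prior example. Compound 4 is therefore estimated at 70 nM, with a likely range from 20 nM to 300 nM.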

Compound 4, half-maximal inhibitory concentration: 11 nM
Beside the measured number, compound 4's estimate is 6.4-fold (0.80 log units) above it; measured number outside the range, below it.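

In this assay the change from 4-methoxyphenyl to 3,4-dimethoxyphenyl gave a 1.2-fold lower number from compound 3 to compound 4 (0.09 log units; within the scatter) and so did not repeat on the core of compound 3 the rise seen on the core of compound 1. The two steps differ by more than the scatter allows: the same change on two cores in this assay, a 7.6-fold higher number (0.88 log units; beyond the scatter) from compound 1 to compound 2 and a 1.2-fold lower number (0.09 log units; within the scatter) from compound 3 to compound 4, 9.3-fold (0.97 log units) apart, beyond the scatter of two such steps. This shows that the result of this methoxy addition does not carry reliably from one core to the other in this series, but two pairs do not show which difference between the cores matters, or how the change would behave on a further core.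

The compounds shown leave open how an amine, a carboxylic acid or a longer alkoxy chain at this same place would read on either core.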